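Aryl piperazine variation on the aminothiophene ketone core

This account rests on a few compounds, and the source may have more. Where it says the series, first, only, none or still open, it means among the compounds named here.

Measured so far in a functional assay on CHO cells with adenosine receptor A1 (Homo sapiens) as the target, read by cAMP accumulation and immunoassay, with a stated time of 6 min, tested at 1 uM; on this read-out lower numbers stand for a stronger effect and higher numbers for a weaker effect at the one concentration tested:
- compound 1 `Nc1scc(CN2CCN(c3cc(Cl)cc(Cl)c3)CC2)c1C(=O)c1ccc(Cl)cc1` gives -69%
- compound 2 `Nc1scc(CN2CCN(c3ccc(F)cc3Cl)CC2)c1C(=O)c1ccc(Cl)cc1` gives -39%
- compound 3 `Nc1scc(CN2CCN(c3ccc([N+](=O)[O-])cc3)CC2)c1C(=O)c1ccc(Cl)cc1` gives -8.3%

Compound 1 stands lowest of the three numbers, that is, it shows the strongest effect at the single concentration; compound 2 lies nearest, compound 3 furthest. Every aryl group so far has been set on the same ring nitrogen of the shared core, and each departure from compound 1 has raised the number: a number 30 percentage points higher from compound 1 to compound 2 (beyond the scatter), a number 60.7 percentage points higher from compound 1 to compound 3 (beyond the scatter), and between the two replacements a number 30.7 percentage points higher from compound 2 to compound 3 (beyond the scatter).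

Compound 4 `Nc1scc(CN2CCN(c3cccc(C(F)(F)F)c3)CC2)c1C(=O)c1ccc(Cl)cc1` is not yet measured. The change from compound 1: 3-(trifluoromethyl)phenyl in place of 3,5-dichlorophenyl on an amine nitrogen in a ring. This is again an exchange of the 3,5-dichlorophenyl on that ring nitrogen, so the two steps out of compound 1 bear directly on it, and both went upward, one modest, one large. A halogenated aryl staying in place resembles the case of compound 2 more than that of compound 3, so a modest rise is expected rather than a large one, though a number near compound 1 cannot be excluded.

The estimate for compound 4 is -45%, within -70% to -15%. This means an expected step of a number 24 percentage points higher from compound 1 to compound 4 (beyond the scatter).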

Compound 4, a percentage reported as activity, at one concentration (the size of the read-out at that concentration, not a potency): -72%
Beside the measured number, compound 4's estimate is 27 percentage points above it; measured number outside the range, below it.
By their numbers in this assay, from the lowest: compounds 4 and 1 (each within the scatter of the next); then compound 2; then compound 3.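

In this assay, the low number is not confined to the 3,5-dichlorophenyl on the amine nitrogen in a ring: 3-(trifluoromethyl)phenyl, which carries fluorine and no chlorine, gives a number 3 percentage points lower from compound 1 to compound 4 (within the scatter), so this exchange cannot be told apart from no change in this read-out. Within the data shown here, it is the first departure from compound 1 that does not raise the number, and the replacement stands well clear of the other two aryl groups, with a number 33 percentage points lower from compound 2 to compound 4 (beyond the scatter) and a number 63.7 percentage points lower from compound 3 to compound 4 (beyond the scatter), so halogen on the aryl group does not by itself decide the outcome, as compound 2 goes against any such reading. Nothing at hand gives a reason for these differences.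

Open, as far as these compounds go, is whether the low number extends to other groups on the same nitrogen, such as an unsubstituted phenyl, a methoxyphenyl or a cyanophenyl. Also open, from the compounds shown here alone, is whether compound 1 and compound 4 would still match when compared by potency over a range of concentrations, or with the rest of the shared core altered.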